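The compounds below may be only part of what the source reports. "The series", "measured", "known", "first", "only" and "open" are said of these compounds alone.

Measured so far in an ADME assay on cells (Hepatocyte, Homo sapiens) for metabolic stability, with a stated time of 30 min; a higher number here means that more of the compound is left, a lower number that less of the compound is left:
- compound 1 `O=c1cc(N2CCN(CC3CCC(NS(=O)(=O)c4ccccc4)CC3)CC2)sc2c([N+](=O)[O-])cc(C(F)(F)F)cc12`: 90.8%
- compound 2 `Cc1ccc(C(=O)OC2CCC(CN3CCN(c4cc(=O)c5cc(C(F)(F)F)cc([N+](=O)[O-])c5s4)CC3)CC2)cc1`: 9.7%
- compound 3 `O=C(OC1CCC(CN2CCN(c3cc(=O)c4cc(C(F)(F)F)cc([N+](=O)[O-])c4s3)CC2)CC1)c1ccc(C(F)(F)F)cc1`: 5.2%

Compound 3 stands at the low end of the three numbers, within the scatter of compound 2 and far from compound 1. The next compound to be measured is compound 4 `O=C(OC1CCC(CN2CCN(c3cc(=O)c4cc(C(F)(F)F)cc([N+](=O)[O-])c4s3)CC2)CC1)C1CCCCC1`. Its change from compound 3 is cyclohexyl in place of 4-(trifluoromethyl)phenyl on a carbonyl carbon.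

Within the data shown here, two measured steps bear on this. Trifluoromethyl in place of methyl on an aromatic carbon gave a number 4.5 percentage points lower from compound 2 to compound 3 (within the scatter), so the one change made so far on this aromatic group left no measurable mark. The large step is a number 81.1 percentage points lower from compound 1 to compound 2 (beyond the scatter), which came with ((4-methylphenyl)carbonyl)oxy in place of (phenylsulfonyl)amino on a saturated ring carbon. Compound 4 keeps the carbonyl and oxygen of compounds 2 and 3, and so stays on the low side of that step. Among the measured compounds shown here, no measured compound carries cyclohexyl at this place, which widens the range upward.

The expected result is no change beyond the scatter, and the estimated step is a number 2.8 percentage points higher from compound 3 to compound 4 (within the scatter). Compound 4 is estimated at 8%, with an expected range of 2% to 25%.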

Compound 4, percent of the compound remaining: 2.8%
Estimate against measurement, compound 4: 5.2 percentage points above; the measured number falls inside the stated range.
By their numbers in this assay, from the lowest: compounds 4, 3 and 2 (each within the scatter of the next); then compound 1.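

In this assay, among these compounds, the aromatic ring on this carbonyl carbon can give way to a saturated ring without a measurable change, whether cyclohexyl replaces 4-(trifluoromethyl)phenyl (a number 2.4 percentage points lower from compound 3 to compound 4 (within the scatter)) or 4-methylphenyl (a number 6.9 percentage points lower from compound 2 to compound 4 (within the scatter)); the earlier compounds showed only a change on the aromatic ring, not the replacement of the ring itself. Compounds 2, 3 and 4 therefore stay together at the low end with either an aromatic or a non-aromatic ring here, and the large gap to compound 1 also holds with cyclohexyl, where (cyclohexylcarbonyl)oxy replaces (phenylsulfonyl)amino on a saturated ring carbon (a number 88 percentage points lower from compound 1 to compound 4 (beyond the scatter)). No accompanying measurement offers an explanation for this result.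

The compounds shown leave open whether any group on this carbonyl carbon can lift the number, for example an amine or a carboxylic acid on a longer chain. They also leave open whether the low numbers go with the carbonyl and oxygen themselves, which an amide link in their place would test.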